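The source may hold more compounds than are shown below. What is called first, only, known or untested is meant among the compounds shown, and "the series" means these compounds.

Measured compounds:
compound 1 `Nc1ccccc1NC(=O)c1ccc(CSC(=S)N2CCN(C3CCCCC3)CC2)cc1` with 16.9% in a functional assay on MGC-803 cells (Homo sapiens) for antiproliferative activity, read by CCK-8 assay, with a stated time of 72 h, tested at 2 uM; on this read-out lower numbers stand for a weaker effect and higher numbers for a stronger effect at the one concentration tested
compound 2 `CC1CCCCN1C(=S)SCc1ccc(C(=O)Nc2ccccc2N)cc1` with 64.4%
compound 3 `Nc1ccccc1NC(=O)c1ccc(CSC(=S)N2CCCc3ccccc32)cc1` with 38.5%

Compound 1 stands lowest of the three numbers in this assay; compound 3 is the nearest, and compound 2 the furthest, both higher by more than the usual scatter. Within the data shown here, the one measured step that compares two compounds differing in a single place is a number 25.9 percentage points lower from compound 2 to compound 3 (beyond the scatter), a change made on a thiocarbonyl carbon and not on the ring nitrogen that compound 4 alters.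

Compound 4 `Nc1ccccc1NC(=O)c1ccc(CSC(=S)N2CCN(c3cnccn3)CC2)cc1` is an unmeasured relative of compound 1, carrying (pyrazin-2-yl in place of cyclohexyl on an amine nitrogen in a ring). Among the measured compounds shown here, no measured pair probes a change at this amine nitrogen, so the step from compound 2 to compound 3 gives only a feel for how much a change of a ring substituent can move the read-out, not its direction here. Given that compound 1 gives 16.9%, a modest rise is expected, as a number 8.1 percentage points higher from compound 1 to compound 4 (within the scatter), but one not clearly beyond the scatter. For compound 4 the expected value is 25%, within 8% to 50%.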

Compound 4, a percentage reported as inhibition, at one concentration (the size of the read-out at that concentration, not a potency): 27.1%
Beside the measured number, compound 4's estimate is 2.1 percentage points below it; low and high end bracket the measured number.
By their numbers in this assay, from the lowest: compound 1; then compound 4; then compound 3; then compound 2.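

In this assay, the amine nitrogen in the ring now has its first single-place comparison: pyrazin-2-yl in place of cyclohexyl gives a number 10.2 percentage points higher from compound 1 to compound 4 (beyond the scatter), a modest step beyond the usual scatter. This shows that the read-out responds to the group on this nitrogen even when the heavy-atom count stays the same, with an aromatic ring carrying two hetero atoms and two hydrogen-bond acceptors replacing a non-aromatic ring of carbon only. Nothing available here accounts for the rise.

A single pair cannot separate the switch to an aromatic ring from the added ring nitrogens, so a phenyl group on the same nitrogen would be the natural comparison. On these data alone, it also remains open how a small methyl group or a longer chain ending in a hydroxyl group would fare there.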